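The source may report more compounds than this note shows. Statements on the series, on what has been measured and on what is new or still open speak of the compounds shown alone.

Series notes. Compound 3 `CN(C)CCn1cnnc1-c1cc(Oc2ccc(NC(=O)N/N=C/c3ccc(F)cc3)cc2F)ccn1` gives 1030 nM in a functional assay on MKN-45 cells (Homo sapiens) for cytotoxicity, read by MTT assay, with a stated time of 72 h (on this read-out lower numbers stand for stronger inhibition and higher numbers for weaker inhibition), the lowest of the three numbers shown, though its gaps to compound 2 `CN(C)CCn1cnnc1-c1cc(Oc2ccc(NC(=O)N/N=C/c3ccc(O)c(Br)c3)cc2F)ccn1`, at 1860 nM, and to compound 1 `CN(C)CCn1cnnc1-c1cc(Oc2ccc(NC(=O)N/N=C/c3ccc(O)c(F)c3)cc2F)ccn1`, at 1970 nM, both lie within the scatter. Compound 4 `CN(C)CCn1cnnc1-c1cc(Oc2ccc(NC(=O)N/N=C/c3ccc(O)cc3O)cc2F)ccn1` is not yet measured; against compound 3 it carries 2,4-dihydroxyphenyl in place of 4-fluorophenyl on a carbon with a double bond to nitrogen. Going by the values given here, the steps that bear on this exchange the group on the carbon with a double bond to nitrogen: a 1.9-fold lower number from compound 1 to compound 3 (0.28 log units; within the scatter) and a 1.8-fold lower number from compound 2 to compound 3 (0.26 log units; within the scatter), both within the scatter. The 3-fluoro-4-hydroxyphenyl of compound 1 and the 3-bromo-4-hydroxyphenyl of compound 2 thus gave no step beyond the scatter against 4-fluorophenyl. For compound 4 no step beyond the scatter is expected either, with only a slight lean toward a higher number: a 1.6-fold higher number from compound 3 to compound 4 (0.19 log units; within the scatter). Compound 4 is therefore estimated at 1600 nM, range 700 nM to 3600 nM.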

Compound 4, half-maximal inhibitory concentration: 2860 nM
Beside the measured number, compound 4's estimate is 1.8-fold (0.25 log units) below it, and the stated range covers the measured number.
By their numbers in this assay, from the lowest: compounds 3, 2, 1 and 4 (each within the scatter of the next, the first and the last beyond it).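

Going by these compounds alone, at the carbon with a double bond to nitrogen, replacing 4-fluorophenyl with 2,4-dihydroxyphenyl gives the first step beyond the scatter in this assay (a 2.8-fold higher number from compound 3 to compound 4 (0.44 log units; beyond the scatter)). Against 3-bromo-4-hydroxyphenyl (a 1.5-fold higher number from compound 2 to compound 4 (0.19 log units; within the scatter)) and 3-fluoro-4-hydroxyphenyl (a 1.5-fold higher number from compound 1 to compound 4 (0.16 log units; within the scatter)), 2,4-dihydroxyphenyl stays within the scatter, so only the two ends of the order separate. No evidence at hand accounts for this step.

The compounds shown leave open how 4-hydroxyphenyl or 2-hydroxyphenyl alone would read at this carbon. They also leave open the reading for groups such as 4-aminophenyl or 4-carboxyphenyl.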